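Swapping the side group on a soluble compound

A few compounds are considered here, and "the series" means these few. Any claim that something is new, unique, unknown or untested is made for them only; others in the source may bear on it.

Among the compounds with values here, in a physicochemical assay for solubility, read by spectrophotometry, in phosphate buffer, with a stated time of 2 h, at pH 7.4 (a higher number here means a more soluble compound, a lower number a less soluble compound), compound 2 (`COc1ccc2[nH]c(C(=O)N3CC(=O)N(Cc4ccccc4)[C@@H](COc4ccc(F)cc4)C3)cc2c1`) gives 17500 nM, the only true number so far. Compound 1 (`COc1ccc2[nH]c(C(=O)N3CC(=O)N(Cc4ccccc4)[C@@H](CN4CCCCC4)C3)cc2c1`) gives > 25000 nM, which is a limit of the assay and not a number.

Compound 3 (`COc1ccc2[nH]c(C(=O)N3CC(=O)N(Cc4ccccc4)[C@@H](CN4CCC(C(C)C)CC4)C3)cc2c1`) keeps the core of compound 2 but carries 4-isopropylpiperidin-1-yl in place of 4-fluorophenoxy, on a saturated chain carbon bound to a saturated ring carbon (4-isopropylpiperidin-1-yl in place of 4-fluorophenoxy on a saturated chain carbon bound to a saturated ring carbon). Within the data shown here, this brings back a piperidine ring like the one in compound 1, now with an isopropyl group attached.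

Among the measured compounds shown here, only one measured step bears on this change: an at least 1.4-fold lower number from compound 1 to compound 2 (0.15 log units; that floor lies within the scatter). It exchanges piperidin-1-yl for 4-fluorophenoxy at that same place, and the size it shows is only a floor, one that lies within the scatter. Given that step, no change beyond the scatter is expected in this assay, with only a slight lean toward a higher number. The expected step is a 1.1-fold higher number from compound 2 to compound 3 (0.06 log units; within the scatter). For compound 3 the estimated solubility is 20000 nM, with an expected range from 10000 nM to 25000 nM.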

Compound 3, solubility: 12000 nM
Estimate against measurement, compound 3: 1.7-fold (0.22 log units) above, within the range that was stated.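

Exchanging 4-fluorophenoxy for 4-isopropylpiperidin-1-yl on a saturated chain carbon bound to a saturated ring carbon gives a 1.5-fold lower number from compound 2 to compound 3 (0.16 log units; within the scatter) in this assay, so this swap of an aromatic ring for a non-aromatic ring holding a nitrogen leaves the two compounds indistinguishable in this read-out. Within the data shown here, the clearer information comes from the two compounds that both carry the piperidine ring: placing isopropyl in place of hydrogen on a saturated ring carbon gives an at least 2.0-fold lower number from compound 1 to compound 3 (0.31 log units; beyond the scatter), the only step in this short series whose printed size passes the scatter. Compound 1 stands at a limit of the assay and not at a true number, so the size of that step is only a floor: the limit of > 25000 nM in this assay, at which 1 of the 3 values shown sits.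

The compounds shown leave open how a methyl group, a hydroxyl group or a carboxylic acid in the place of the isopropyl would read in this assay, and so whether the isopropyl result reflects something particular to that group. They also leave open how a morpholine ring in the place of the piperidine ring would read, and how far the true number for compound 1 lies from that of its isopropyl partner.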